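A few compounds are considered here, and "the series" means these few. Any claim that something is new, unique, unknown or untested is made for them only; others in the source may bear on it.

Measured compounds in an in vitro assay on HEK-tsA201 cells for antagonist activity at Neuronal acetylcholine receptor; alpha3/beta4 (Homo sapiens), read by fluorescence and calcium flux; a lower number here means a stronger inhibitor, a higher number a weaker inhibitor:
Compound 1 `CCCOc1ccc(C(=O)Nc2cccc(Br)n2)cc1`: compound 1 gives > 100000 nM, a limit of the assay.
Compound 2 `CCCOc1ccc(C(=O)Nc2cccc(Cl)n2)cc1`: compound 2 gives > 100000 nM, a limit of the assay.
Compound 3 `CCCOc1ccc(C(=O)Nc2cccc(Nc3cccc(F)c3)n2)cc1`: compound 3 gives > 100000 nM, a limit of the assay.

Compound 3 stands only at a limit, as do the two others: the limit of > 100000 nM in this assay, at which 3 of the 3 values shown sit. The steps between them, a step that the two limits leave unreadable from compound 1 to compound 2, a step that the two limits leave unreadable from compound 1 to compound 3 and a step that the two limits leave unreadable from compound 2 to compound 3, therefore carry no size.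

Compound 4 `CCCOc1ccc(C(=O)Nc2cccc(Nc3ccc(Cl)cc3)n2)cc1` differs from compound 3 in one place: 4-chlorophenyl in place of 3-fluorophenyl on a nitrogen on an aromatic ring. Going by the values given here, no measured step bears on this exchange of one phenylamino group for another, and compound 3 itself sits at the limit. The expected step, a number no higher from compound 3 to compound 4 (the limit leaves the size open), is thus unreadable. Compound 4 is expected at 100000 nM, between 30000 nM and 300000 nM, most likely again a limit.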

Compound 4, half-maximal inhibitory concentration: > 100000 nM
Compound 4: only a limit was reported (the forecaster's own chance of this, stated with the estimate: 85%); the middle value sits exactly at the limit.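

Compound 4 joins compound 1, compound 2 and compound 3 at the same limit, so no step among these compounds can be read: the limit of > 100000 nM in this assay, at which 4 of the 4 values shown sit.

Which change to the shared core would bring a readable value in this assay remains open.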